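Compound 1 to compound 3: exchange of the aryl group

The source may hold more compounds than are shown below. What is called first, only, known or untested is meant among the compounds shown, and "the series" means these compounds.

In a functional assay on U-251 cells (Homo sapiens) for inhibition, read by MTT assay, with a stated time of 2 days (on this read-out higher numbers stand for weaker inhibition of growth and lower numbers for stronger inhibition of growth), compound 1 (`Nc1ccccc1NC(=O)CCCNCC(=O)Nc1ccc(Br)cc1`) gives 10400 nM and compound 2 (`Nc1ccccc1NC(=O)c1ccc(NCC(=O)Nc2ccc([N+](=O)[O-])cc2)cc1`) gives 8200 nM and these two numbers lie within the scatter of each other. Among the measured compounds shown here, compound 1 therefore sits level with the only other measured compound. Compound 3 (`Nc1ccccc1NC(=O)CCCNCC(=O)Nc1cc(Cl)ccc1Cl`) carries 2,5-dichlorophenyl in place of 4-bromophenyl on an amide-type nitrogen. For the measured compounds named here, no measured step covers this exchange. No shift beyond the scatter is expected in this assay in either direction. The estimated 1.3-fold lower number from compound 1 to compound 3 (0.11 log units; within the scatter) is small. For compound 3 the estimate is 8000 nM with an expected range from 3500 nM to 18000 nM on this read-out.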

Compound 3, concentration for 50% growth inhibition: 44000 nM
For compound 3 the middle estimate is 5.5-fold (0.74 log units) below the measured one, and the stated range ends below it.
By their numbers in this assay, from the lowest: compounds 2 and 1 (each within the scatter of the next); then compound 3.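

In this assay, among the compounds shown here, the aryl group on the amide-type nitrogen is the first place where a single change registers: 2,5-dichlorophenyl in place of 4-bromophenyl gives a 4.2-fold higher number from compound 1 to compound 3 (0.63 log units; beyond the scatter), meaning weaker inhibition of growth. This position therefore does not accept every halogenated phenyl equally, although the step is modest. Nothing available bears on the cause of this step.

Going by these compounds, whether the step follows from the kind of halogen, their number or their placement remains open, as all of these change together. A plain phenyl group on the same nitrogen would provide a reference for both halogenated compounds.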